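A Bromophenyl Swap on the Weaker of Two Compounds

The source may hold more compounds than are shown below. What is called first, only, known or untested is meant among the compounds shown, and "the series" means these compounds.

Among the measured compounds shown here, only two compounds have numbers so far in a functional assay on HL-60 cells (Homo sapiens) for antiproliferative activity, read by MTT assay, with a stated time of 72 h; a lower number here means a stronger inhibitor, a higher number a weaker inhibitor. There, compound 1 (`CC(C)(C)c1ccc(OCCCON2C(N)=NC(N)=NC23CCSCC3)cc1`) gives 280 nM, while compound 2 (`NC1=NC2(CCOCC2)N(OCCCOc2ccc(F)cc2)C(N)=N1`) gives 2380 nM. That is the higher of the two numbers, making compound 2 the weaker inhibitor, and the gap lies beyond the usual scatter.

Compound 3 (`NC1=NC2(CCOCC2)N(OCCCOc2ccccc2Br)C(N)=N1`) alters compound 2 in one place: 2-bromophenyl in place of 4-fluorophenyl on an oxygen on a saturated carbon. In words, 2-bromophenyl stands in place of 4-fluorophenyl on an oxygen on a saturated carbon.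

For the measured compounds named here, no measured pair shows a change in one place alone, and compound 1 and compound 2 differ in more than one, so their gap is only a loose guide. A moderate move toward a lower number is expected, a 2.2-fold lower number from compound 2 to compound 3 (0.34 log units; beyond the scatter), though the result could stay within the scatter. For compound 3, the estimated value is 1100 nM, with an expected range from 350 nM to 3000 nM.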

Compound 3, half-maximal inhibitory concentration: 610 nM
The estimate for compound 3 lay 1.8-fold (0.26 log units) above the measured number; measured number inside the range.
By their numbers in this assay, from the lowest: compound 1; then compound 3; then compound 2.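

In this assay, among the compounds shown here, replacing 4-fluorophenyl with 2-bromophenyl gives a 3.9-fold lower number from compound 2 to compound 3 (0.59 log units; beyond the scatter), the first change in one place alone that can be read here. It shows that the group on this oxygen affects the number, even though the two groups match in heavy-atom count, each has one aromatic ring of carbon only, and neither has hydrogen-bond donors or acceptors. Nothing measured here explains why the number fell.

From the compounds shown here alone, this single step changes the halogen from fluorine to bromine and also moves it on the ring, so the contribution of each change remains unknown. The compounds shown also leave open how a plain phenyl group with no halogen, or an amine in place of the aromatic ring, would behave at this position.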